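The source may hold more compounds than are shown below. What is called first, only, known or untested is meant among the compounds shown, and "the series" means these compounds.

Compound 3 `CN1CCN(CCNC(=O)n2c(=O)n(C)c3ccccc32)CC1` carries a methyl on an aromatic nitrogen of the shared core. In a functional assay for antagonist activity at 5-hydroxytryptamine receptor 4 (Cavia porcellus) (on this read-out higher numbers stand for higher potency (the scale is a negative logarithm) and lower numbers for lower potency), compound 3 reaches only the limit < 6. Compound 1 `CC(C)n1c(=O)n(C(=O)NCCN2CCN(C)CC2)c2ccccc21` bears an isopropyl in the same place, and in this assay compound 1 likewise shows the limit < 6. Compound 2 `C=CCn1c(=O)n(C(=O)NCCN2CCN(C)CC2)c2ccccc21` has an allyl there, and in this assay compound 2 also sits at the limit < 6. The steps a step that the two limits leave unreadable from compound 1 to compound 3, a step that the two limits leave unreadable from compound 1 to compound 2 and a step that the two limits leave unreadable from compound 2 to compound 3 stay unreadable because of the limit of < 6 in this assay, at which 3 of the 3 values shown sit. Compound 4 `CCCCn1c(=O)n(C(=O)NCCN2CCN(C)CC2)c2ccccc21` differs from compound 3 by propyl in place of hydrogen on a saturated chain carbon bound to an aromatic nitrogen. With no readable step to lean on, the expected step that the limit leaves unreadable from compound 3 to compound 4 in this assay rests on the shared limit alone. Compound 4 is estimated at 5.5, with a range from 4.5 to 6.3, and most likely again only a limit.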

Compound 4, negative logarithm of the antagonist equilibrium constant: < 6
Compound 4 was reported as a limit (the forecaster's own chance of this, stated with the estimate: 75%); the middle value is on the limit's open side.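

Within the data shown here, no step from compound 1, compound 2 or compound 3 to compound 4 can be read, because each compound stands only as a limit: the limit of < 6 in this assay, at which 4 of the 4 values shown sit. Going by these compounds, whether swapping methyl, isopropyl, allyl or butyl on the aromatic nitrogen shifts potency at all in this assay stays open.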